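The compounds below may be only part of what the source reports. "The series", "measured", "known", "first", "only" and "open" are said of these compounds alone.

In a functional assay on HeLa cells (Homo sapiens) for cytotoxicity, read by CCK-8 assay (on this read-out higher numbers stand for weaker inhibition and lower numbers for stronger inhibition), compound 1 (`O=C(Nc1ccc(O)cc1)c1ncc(-c2ccccc2)o1`) gives 780 nM as its value. Compound 2 (`CN(C)c1ccc(NC(=O)c2ncc(-c3ccccc3)o2)cc1`) gives > 30000 nM as a limit of the assay and not a number. Compound 3 (`O=C(Nc1ccc(Cl)cc1)c1ncc(-c2ccccc2)o1`) has chloro in place of dimethylamino on an aromatic carbon, para to a large group (chloro in place of dimethylamino on an aromatic carbon). For the measured compounds named here, the one measured step bearing on this is an at least 38-fold higher number from compound 1 to compound 2 (1.58 log units; beyond the scatter) with dimethylamino entering for hydroxy, a large step, so a large move toward stronger inhibition is expected once dimethylamino leaves, though chloro itself is untested. The expected change is an at least 7.5-fold lower number from compound 2 to compound 3 (0.87 log units; beyond the scatter) in this assay as estimated here. The estimated value for compound 3 is 4000 nM with 800 nM to 25000 nM as its range.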

Compound 3, half-maximal inhibitory concentration: > 30000 nM
Compound 3 was reported as a limit; the forecaster's own chance of this, stated with the estimate: 20%; at least 7.5-fold (0.87 log units) between middle value and limit.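

Chloro in place of hydroxy on this aromatic carbon gives an at least 38-fold higher number from compound 1 to compound 3 (1.58 log units; beyond the scatter) in this assay, so the loss seen with dimethylamino is not confined to that one replacement. Of the three compounds, only compound 1, with hydroxy, gives a value that is not a limit. The step from dimethylamino to chloro cannot be read, because both compounds sit at the same limit: the limit of > 30000 nM in this assay, at which 2 of the 3 values shown sit.

Going by these compounds, whether an amine, a methoxy group or a carboxylic acid at this position would keep any of the inhibition of compound 1 remains open. On these data alone, how much weaker compound 2 and compound 3 truly are also remains open.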